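The compounds below may be only part of what the source reports. "The series", "measured", "known", "first", "only" and "open" are said of these compounds alone.

Measured in a functional assay on HT-29 cells (Homo sapiens) for cytotoxicity, read by sulforhodamine B assay, with a stated time of 2 days, tested at 100 uM; a lower number here means less inhibition, a higher number more inhibition at the concentration tested (going by the name of the read-out):
Compound 1 `CCCc1n[nH]c2c(=O)n(NC(=O)c3ccncc3)c(-c3cccc(OC)c3)nc12` gives 0.07%
Compound 2 `O=C(Nn1c(-c2cccc([N+](=O)[O-])c2)nc2c(-c3ccc(F)cc3)n[nH]c2c1=O)c1cccnc1` gives 24.7%
Compound 3 `COc1cccc(-c2nc3c(-c4ccco4)n[nH]c3c(=O)n2NC(=O)c2cccnc2)c1` gives 12.8%

Compound 2 stands highest of the three in this assay; the nearest number is that of compound 3, a gap beyond the scatter, and the furthest is that of compound 1, also beyond the scatter. Compound 4 `O=C(Nn1c(-c2cccc([N+](=O)[O-])c2)nc2c(-c3cccs3)n[nH]c2c1=O)c1cccnc1` is not yet measured. It differs from compound 2 in one place: thiophen-2-yl in place of 4-fluorophenyl on an aromatic carbon. Within the data shown here, no pair of measured compounds differs in only this way, so the step has no direct precedent. Compound 3 also carries a five-membered ring at this place, but alongside a different group elsewhere, so its number is only a loose hint. A moderate decrease, or no change beyond the scatter, is expected. Compound 4 is expected to give 18%, within 5% to 32%. The step this estimate implies is a number 6.7 percentage points lower from compound 2 to compound 4 (within the scatter), expected rather than established.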

Compound 4, a percentage reported as inhibition, at one concentration (the size of the read-out at that concentration, not a potency): 3.9%
Compound 4: the middle estimate sits 14.1 percentage points above what was measured, outside the stated range (below it).
By their numbers in this assay, from the lowest: compounds 1, 4 and 3 (each within the scatter of the next, the first and the last beyond it); then compound 2.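

With the rest of the molecule unchanged, the aromatic carbon of the five-membered ring with 2 nitrogen proves sensitive in this assay: thiophen-2-yl in place of 4-fluorophenyl gives a number 20.8 percentage points lower from compound 2 to compound 4 (beyond the scatter). Among these compounds, this is the first single-place comparison, and it ties part of the number of compound 2 to the 4-fluorophenyl group. Nothing at hand explains the step, and this pair alone cannot separate ring size, the sulfur and the loss of fluorine.

Open, on these data alone, is whether the step carries over when other groups elsewhere on the core change. Also open, as far as these compounds go, is how a plain phenyl or an amine at this carbon would read.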